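The source may report more compounds than this note shows. Statements on the series, on what has been measured and on what is new or still open speak of the compounds shown alone.

Measured in a functional assay on brain (Rattus norvegicus, strain Wistar) for inhibition; a higher number here means a weaker inhibitor, a lower number a stronger inhibitor:
- compound 1 `COc1ccc(-c2c(C)[nH]c(=O)n2C2CCCCC2)cc1`: 20400 nM
- compound 2 `Cc1[nH]c(=O)n(C2CCCCC2)c1-c1ccc(CC(C)C)cc1`: 10900 nM
- compound 3 `CCCCCc1ccc(-c2c(C)[nH]c(=O)n2C2CCCCC2)cc1`: 10600 nM

The three compounds share a core and differ only in the group on one aromatic carbon. Compound 3 is not separated from the other two: a 1.9-fold lower number from compound 1 to compound 3 (0.28 log units; within the scatter) and a 1.0-fold lower number from compound 2 to compound 3 (0.01 log units; within the scatter) both lie within the scatter. So does a 1.9-fold lower number from compound 1 to compound 2 (0.27 log units; within the scatter).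

Compound 4 `CCCCCOc1ccc(-c2c(C)[nH]c(=O)n2C2CCCCC2)cc1` is built from compound 3 by one change, pentyloxy in place of pentyl on an aromatic carbon, para to a large group: pentyloxy in place of pentyl on an aromatic carbon. Among the compounds with values here, no measured step makes exactly this change. The nearest evidence is the exchange of methoxy for pentyl, a 1.9-fold lower number from compound 1 to compound 3 (0.28 log units; within the scatter), which connects an ether-linked group with a plain chain and stays within the scatter. A step beyond the scatter in this assay is therefore not expected. The expected change is a 1.0-fold higher number from compound 3 to compound 4 (0.02 log units; within the scatter).

For compound 4 the estimated value is 11000 nM, with an expected range from 4500 nM to 25000 nM.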

Compound 4, half-maximal inhibitory concentration: 9100 nM
The estimate for compound 4 lay 1.2-fold (0.08 log units) above the measured number; low and high end bracket the measured number.
By their numbers in this assay, from the lowest: compounds 4, 3, 2 and 1 (each within the scatter of the next, the first and the last beyond it).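

In this assay pentyloxy in place of pentyl gives a 1.2-fold lower number from compound 3 to compound 4 (0.07 log units; within the scatter) and pentyloxy in place of isobutyl gives a 1.2-fold lower number from compound 2 to compound 4 (0.08 log units; within the scatter) so on this aromatic carbon the chain linked through oxygen cannot be told apart from the two plain chains. Within the data shown here, what is new is the extension of methoxy to pentyloxy, which gives a 2.2-fold lower number from compound 1 to compound 4 (0.35 log units; beyond the scatter) and is the first step to pass beyond the scatter, though only modestly; neither plain chain does so against compound 1. The compounds shown leave open whether a longer chain such as decyloxy would carry the number further in the same direction, and whether an amine or a carboxylic acid on this carbon would be accepted. No measurement given here explains this modest step.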